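The compounds below may be only part of what the source reports. "The series", "measured", "known", "first", "only" and "open" are said of these compounds alone.

Compound 1 `C[C@H](Nc1ncnc2[nH]cnc12)c1cc2ccccn2c(=O)c1-c1ccccc1` is the reference point here. In an ADME assay on microsomes from liver (Mus musculus), read by LC-MS, using NADPH, with a stated time of 30 min, tested at 1 uM (a higher number here means that more of the compound is left, a lower number that less of the compound is left), compound 1 gives 51%, the highest of the three numbers measured; compound 3 `Cc1c(F)ccc2cc([C@H](C)Nc3ncnc(N)c3C#N)c(-c3ccccc3)c(=O)n12` gives 30% and compound 2 `Cc1cccc2cc([C@H](C)Nc3ncnc4[nH]cnc34)c(-c3ccccc3)c(=O)n12` gives 4%. Compound 4 `C[C@H](Nc1ncnc2[nH]cnc12)c1cc2ccc(F)cn2c(=O)c1-c1ccccc1` has not been measured. It differs from compound 1 in one place: fluoro in place of hydrogen on an aromatic carbon. Within the data shown here, the only single measured change from compound 1 is a number 47 percentage points lower from compound 1 to compound 2 (beyond the scatter), a methyl rather than a fluoro, so it bears on this step only loosely. Compound 3 differs from compound 1 in several places at once, and its value stands between those of compound 1 and compound 2. Among the measured compounds shown here, no measured step shows a fluoro alone, so for compound 4 a change of a number 6 percentage points lower from compound 1 to compound 4 (within the scatter) is expected, within the scatter. Compound 4 is estimated at 45%, with a range from 25% to 65%.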

Compound 4, percent of the compound remaining: 94%
The estimate for compound 4 lay 49 percentage points below the measured number, outside the stated range (above it).
By their numbers in this assay, from the lowest: compound 2; then compound 3; then compound 1; then compound 4.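

In this assay the fluoro on an aromatic carbon two atoms from the ring nitrogen gives a number 43 percentage points higher from compound 1 to compound 4 (beyond the scatter) and so shows that swapping one hydrogen at this position can shift the result strongly upward. Among these compounds, the only other single change, a methyl in a different place, gives a number 47 percentage points lower from compound 1 to compound 2 (beyond the scatter) instead and so shows that the direction depends on the group, the place or both. No measurement shown explains this rise. As far as these compounds go, whether a chloro or a methoxy at this position would behave like the fluoro stays open.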